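A few compounds are considered here, and "the series" means these few. Any claim that something is new, unique, unknown or untested is made for them only; others in the source may bear on it.

Measured compounds in this set:
- compound 1, `CCN(C1CCCC1)S(=O)(=O)c1ccc(NC(=O)NCc2ccncc2)cc1`: 60 nM
- compound 2, `CN(C1CCCC1)S(=O)(=O)c1ccc(NC(=O)NCc2ccncc2)cc1`: 123 nM
- compound 3, `O=C(NCc1ccncc1)Nc1ccc(S(=O)(=O)c2ccccc2)cc1`: 85 nM

In an assay on isolated protein for activation of Nicotinamide phosphoribosyltransferase (Homo sapiens) (a lower number here means that less compound is needed, a higher number that more compound is needed for the effect), compound 3 stands second highest of the three numbers; its nearest neighbour is compound 1, its furthest compound 2, and both gaps are within the scatter, so no order among the three is claimed. Within the data shown here, the only step that lies beyond the scatter is a 2.1-fold higher number from compound 1 to compound 2 (0.31 log units; beyond the scatter), a modest one.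

The next compound is compound 4, `CCN(CC)S(=O)(=O)c1ccc(NC(=O)NCc2ccncc2)cc1`. The change from compound 3 is diethylamino in place of phenyl on a sulfonyl sulfur. Among the measured compounds shown here, the steps that bear on it run the other way: a 1.4-fold higher number from compound 1 to compound 3 (0.15 log units; within the scatter) and a 1.4-fold lower number from compound 2 to compound 3 (0.16 log units; within the scatter), both within the scatter, which shows that replacing a dialkylamino by phenyl on the sulfonyl sulfur has so far moved the number little. Diethylamino differs from both of those amino groups, so the closest analogue is compound 1 rather than compound 2, but the two amino compounds themselves sit only a modest step apart.

The expectation for compound 4 is therefore a step of a 1.1-fold higher number from compound 3 to compound 4 (0.02 log units; within the scatter) in this assay, that is no change beyond the scatter. The number expected for compound 4 is 90 nM, with a range from 45 nM to 180 nM.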

Compound 4, half-maximal effective concentration: 384 nM
The estimate for compound 4 lay 4.3-fold (0.63 log units) below the measured number; measured number outside the range, above it.
By their numbers in this assay, from the lowest: compounds 1, 3 and 2 (each within the scatter of the next, the first and the last beyond it); then compound 4.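

Notes on the sulfonyl sulfur position: in this assay, the change to diethylamino gives a 4.5-fold higher number from compound 3 to compound 4 (0.65 log units; beyond the scatter), so the earlier near-equality of phenyl and the dialkylamino groups on the sulfonyl sulfur holds only for the two amino groups that carry cyclopentyl, and not for dialkylamino groups in general. Among the sulfonamides, ethyl in place of cyclopentyl on the sulfonamide nitrogen gives a 6.4-fold higher number from compound 1 to compound 4 (0.81 log units; beyond the scatter), and diethylamino in place of cyclopentyl(methyl)amino gives a 3.1-fold higher number from compound 2 to compound 4 (0.49 log units; beyond the scatter), so in these compounds the cyclopentyl group goes with the lower numbers, while the amino nitrogen alone does not. No measurement on hand accounts for these steps.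

As far as these compounds go, it remains open whether the cyclopentyl group matters as a ring, or whether a longer chain such as n-butyl or a cyclohexyl group on the sulfonamide nitrogen would give a number like that of compound 1. Also open, from the compounds shown here alone, is how dimethylamino, or a piperidine ring that takes in the sulfonamide nitrogen, would read in this assay.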